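Ethyl to tert-butyl on the ester of compound 2

The source may hold more compounds than are shown below. What is called first, only, known or untested is meant among the compounds shown, and "the series" means these compounds.

Two compounds of this series carry a measurement in an ADME assay on WI-38 cells (Homo sapiens) for inhibition, read by CellTiter-Glo, with a stated time of 48 h, tested at 100 uM; a lower number here means less inhibition, a higher number more inhibition at the concentration tested (going by the name of the read-out). Compound 1 `CC(C)(C)OC(=O)/C=C\NC(=O)[C@@H](O)C(C)(C)CO` gives 26% in this assay. Compound 2 `CCOC(=O)/C=C/NC(=O)[C@@H](O)C(C)(C)CO` gives -6% in this assay, the lowest of the two numbers, with compound 1 the nearest neighbour and standing higher by a margin beyond the usual scatter. Within the data shown here, no pair of measured compounds differs in a single place, so no measured step is available to guide the next one.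

Compound 3 `CC(C)(C)OC(=O)/C=C/NC(=O)[C@@H](O)C(C)(C)CO` is the next compound in line, not yet measured. Its difference from compound 2 is tert-butyl in place of ethyl on an oxygen next to a carbonyl group. Without a measured step of this kind, the account rests on the two numbers alone: compound 1, which also carries a tert-butyl group, sits well above compound 2.

On that basis compound 3 is expected to show a small rise in inhibition relative to compound 2, a step of a number 14 percentage points higher from compound 2 to compound 3 (beyond the scatter) that may still lie within the scatter. Compound 3 is therefore estimated at 8% in this assay, between -10% and 28%.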

Compound 3, a percentage reported as inhibition, at one concentration (the size of the read-out at that concentration, not a potency): 14%
Beside the measured number, compound 3's estimate is 6 percentage points below it; the measured number falls inside the stated range.
By their numbers in this assay, from the lowest: compound 2; then compound 3; then compound 1.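

In this assay, the ester position now has a measured step of its own: tert-butyl in place of ethyl on an oxygen next to a carbonyl group goes with a number 20 percentage points higher from compound 2 to compound 3 (beyond the scatter). The double bond has one too, as the change from a Z to an E drawing goes with a number 12 percentage points lower from compound 1 to compound 3 (beyond the scatter), so the number in this series responds separately to the ester group and to the drawn configuration. The second step can be tied to the double bond alone, as nothing else in the structures separates the pair: the fact that compounds 1 and 3 differ only in the configuration as drawn

The compounds shown leave open how the number moves with other groups on this oxygen, such as a longer chain or a benzyl group, or with a free carboxylic acid in place of the ester. They also leave open whether the step between the Z and E drawings has a similar size with ethyl on the ester, as the pair shown here carries tert-butyl in both forms.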